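A few compounds are considered here, and "the series" means these few. Any claim that something is new, unique, unknown or untested is made for them only; others in the source may bear on it.

Compounds tested in a functional assay on MCF7 cells (Homo sapiens) for cytotoxicity, read by MTT assay, with a stated time of 72 h; on this read-out higher numbers stand for weaker inhibition and lower numbers for stronger inhibition:

- compound 1 `CNC(=O)c1cc(Oc2ccc(C3=NNC(c4ccc(C#N)cc4)C3)cc2)ccn1`: "not determined" (no result reported)
- compound 2 `CNC(=O)c1cc(Oc2ccc(C3=NNC(c4ccc(Cl)c(Cl)c4)C3)cc2)ccn1`: "not determined" (no result reported)
- compound 3 `CNC(=O)c1cc(Oc2ccc(C3CC(c4ccc([N+](=O)[O-])cc4)=NN3)cc2)ccn1`: 8030 nM

Of these three entries, only compound 3 has a number, 8030 nM. Compound 1 and compound 2 have no result, so compound 3 cannot be ranked against either of them, and its value stands alone as the only reference point in this small set.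

The next compound to be tested is compound 4 `CNC(=O)c1cc(Oc2ccc(C3CC(c4ccc(Cl)cc4)=NN3)cc2)ccn1`. It keeps the core of compound 3 and differs in one place, with chloro in place of nitro on an aromatic carbon, para to a large group, so that 4-nitrophenyl becomes 4-chlorophenyl: chloro in place of nitro on an aromatic carbon.

For the measured compounds named here, no measured pair in the set shows what a single change does in this assay, so the size of this step has no direct precedent here. The expectation therefore rests on compound 3 at 8030 nM, and no step beyond the usual scatter is expected, with at most a slight lean towards stronger inhibition. The expected change is a 1.3-fold lower number from compound 3 to compound 4 (0.13 log units; within the scatter). For compound 4 the estimated value is 6000 nM, with an expected range from 2000 nM to 18000 nM.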

Compound 4, half-maximal inhibitory concentration: 15300 nM
For compound 4 the middle estimate is 2.6-fold (0.41 log units) below the measured one; the range from low to high includes it.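

In this assay the set now holds its first comparison of compounds that differ in one place: chloro in place of nitro on an aromatic carbon gives a 1.9-fold higher number from compound 3 to compound 4 (0.28 log units; within the scatter). At this place, para to a large group, the 4-nitrophenyl and 4-chlorophenyl forms therefore cannot be told apart on this read-out, even though nitro, with 3 heavy atoms and 2 hydrogen-bond acceptors, gives way to chloro, with 1 heavy atom and no hydrogen-bond acceptors. Nothing among the available measurements offers an explanation for this result.

Any steps to compound 1 and compound 2 cannot be read, as neither compound has a number. As far as these compounds go, what remains open is whether any group at this place can move the number beyond the usual scatter, and what an amine, a methoxy group or a carboxylic acid would do there, since this single step covers only nitro and chloro.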